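The source may report more compounds than this note shows. Statements on the series, on what has been measured and on what is new or still open speak of the compounds shown alone.

Compound 3 `CC1(C)[C@H]2CC[C@]1(C)N(Cc1cn(-c3ccccc3)nn1)C(=O)C2` is the parent of this set. In a functional assay on HepG2 cells (Homo sapiens) for inhibition, read by MTT assay, with a stated time of 24 h (a lower number here means a stronger inhibitor, a higher number a weaker inhibitor), compound 3 gives 90 nM, which places it second highest of the three numbers available. Its nearest neighbour is compound 1 `CC1(C)[C@H]2CC[C@]1(C)N(Cc1cn(-c3ccccc3C#N)nn1)C(=O)C2`, which gives 180 nM; the two sit within the scatter of each other. Furthest from it is compound 2 `CC1(C)[C@H]2CC[C@]1(C)N(Cc1cn(-c3cccc(C#N)c3)nn1)C(=O)C2`, which gives 40 nM in this assay, a modest step beyond the scatter.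

Compound 4 `Cc1cccc(-n2cc(CN3C(=O)C[C@@H]4CC[C@@]3(C)C4(C)C)nn2)c1` is not yet measured. It differs from compound 3 by methyl in place of hydrogen on an aromatic carbon, on an aromatic carbon of a six-membered aromatic ring of carbon only.

Among the compounds with values here, two measured steps touch the same ring. The step of a 2.3-fold higher number from compound 2 to compound 3 (0.35 log units; beyond the scatter) shows that the cyano at the position that compound 2 carries matters modestly, while the step of a 2.0-fold lower number from compound 1 to compound 3 (0.30 log units; within the scatter) stays within the scatter. Methyl is a different group from cyano, with no hydrogen-bond acceptors, so no direct precedent exists. Compound 4 is therefore expected to land near compound 3, with at most a small step, a 1.3-fold lower number from compound 3 to compound 4 (0.11 log units; within the scatter), in this assay. The estimate for compound 4 is 70 nM, within a range of 30 nM to 180 nM.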

Compound 4, half-maximal inhibitory concentration: 300 nM
The estimate for compound 4 lay 4.3-fold (0.63 log units) below the measured number, outside the stated range (above it).
By their numbers in this assay, from the lowest: compound 2; then compounds 3, 1 and 4 (each within the scatter of the next, the first and the last beyond it).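

Until now, the nitrile on this phenyl ring had either lowered the number or stayed within the scatter; in this assay the step of a 3.3-fold higher number from compound 3 to compound 4 (0.52 log units; beyond the scatter) shows that a methyl on this aromatic carbon can raise it. At this one place the choice of group matters: the step of a 7.5-fold higher number from compound 2 to compound 4 (0.88 log units; beyond the scatter) sets methyl and nitrile clearly apart, while the step of a 1.7-fold higher number from compound 1 to compound 4 (0.22 log units; within the scatter) lies within the scatter, so 3-methylphenyl and 2-cyanophenyl cannot be told apart here. Nothing given here accounts for the difference between methyl and nitrile.

The compounds shown leave open whether the rise is particular to methyl or extends to a larger alkyl chain such as ethyl. They also leave open how a methoxy group, an amine or a carboxylic acid on this carbon would read.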